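The source may report more compounds than this note shows. Statements on the series, on what has been measured and on what is new or still open speak of the compounds shown alone.

Measured compounds:
- Compound 1 `CCN1CCN(Cc2c(OC)cc(Oc3cccc(Nc4ccccc4)c3)cc2OC)CC1`: in a functional assay on SW-620 cells (Homo sapiens) for inhibition, read by MTT assay, with a stated time of 72 h (on this read-out higher numbers stand for weaker inhibition and lower numbers for stronger inhibition), compound 1 gives > 20000 nM, a limit of the assay.
- Compound 2 `COc1cc(Oc2cccc(Nc3ccccc3)c2)cc(OC)c1CNC1CC1`: in this assay compound 2 gives > 20000 nM, again a limit.
- Compound 3 `COc1ccc(CNCc2c(OC)cc(Oc3cccc(Nc4ccccc4)c3)cc2OC)cc1`: in this assay compound 3 gives 6970 nM, the only number in the set.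

Compound 3 therefore stands alone as the sole measurable point; the other two sit at the limit of > 20000 nM in this assay, at which 2 of the 3 values shown sit. The steps of an at least 2.8-fold lower number from compound 1 to compound 3 (0.45 log units; beyond the scatter) and an at least 2.8-fold lower number from compound 2 to compound 3 (0.45 log units; beyond the scatter) both lead from a limit down to the number of compound 3, while a step that the two limits leave unreadable from compound 1 to compound 2 stays unreadable between two limits.

Compound 4 `COc1cc(Oc2cccc(Nc3ccccc3)c2)cc(OC)c1CN[C@H](C)c1ccccc1` differs from compound 3 by 1-phenylethyl in place of 4-methoxybenzyl on an amine nitrogen. Going by the values given here, no measured step changes the substituent on the amine nitrogen in this way; the two readable steps only show that compound 3 carries a benzyl-type amine and the limit compounds do not. On that basis the change is expected to stay within the scatter, as a 1.1-fold higher number from compound 3 to compound 4 (0.06 log units; within the scatter). Compound 4 is estimated at 8000 nM, between 3000 nM and 22000 nM.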

Compound 4, half-maximal inhibitory concentration: 18700 nM
The estimate for compound 4 lay 2.3-fold (0.37 log units) below the measured number; measured number inside the range.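

On the amine nitrogen, the exchange of 4-methoxybenzyl for 1-phenylethyl is not neutral in this assay: the result is a 2.7-fold higher number from compound 3 to compound 4 (0.43 log units; beyond the scatter). This single step removes an oxygen and adds a defined stereocentre together, so it does not tell the two changes apart. Only floors can be read against the two limit compounds, an at least 1.0-fold lower number from compound 2 to compound 4 (0.02 log units; that floor lies within the scatter) and an at least 1.0-fold lower number from compound 1 to compound 4 (0.02 log units; that floor lies within the scatter), so an aromatic ring on the amine substituent does not by itself secure a clear separation from them, and both comparisons rest on a limit: the limit of > 20000 nM in this assay, at which 2 of the 4 values shown sit.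

On these data alone, it remains open whether the methoxy group or the branching methyl carbon accounts for the step. An unsubstituted benzyl on the same nitrogen would separate the two, and the opposite configuration of the 1-phenylethyl group is also unresolved.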